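A few compounds are considered here, and "the series" means these few. Any claim that something is new, unique, unknown or untested is made for them only; others in the source may bear on it.

In a functional assay on MT4 cells (Homo sapiens) for cytotoxicity (a higher number here means that more compound is tolerated, a lower number that less compound is tolerated), compound 1 (`CCc1c(O)nc(SCC(=O)c2ccc(F)cc2)nc1Cc1cccc2ccccc12`) shows >= 240000 nM, which is a limit and not a number. Compound 2 (`CCc1c(O)nc(SCC(=O)OC)nc1Cc1cccc2ccccc12`) likewise gives only a limit, >= 196000 nM. Compound 3 (`CC(C)c1c(O)nc(SCC(=O)c2ccc(F)cc2)nc1Cc1cccc2ccccc12`) turns the ethyl of compound 1 into isopropyl: methyl in place of hydrogen on a saturated chain carbon bound to an aromatic carbon and a saturated chain carbon. For the measured compounds named here, the only measured step, a step that the two limits leave unreadable from compound 1 to compound 2, offers no size to carry over, so no change beyond the scatter is expected in this assay, and the estimated step is an at least 1.2-fold lower number from compound 1 to compound 3 (0.07 log units; that floor lies within the scatter). Compound 3 is estimated at 200000 nM, with an expected range of 60000 nM to 300000 nM.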

Compound 3, half-maximal cytotoxic concentration: 186000 nM
The estimate for compound 3 lay 1.1-fold (0.03 log units) above the measured number; the measured number falls inside the stated range.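

In this assay, compound 3 gives 186000 nM, the first actual number among the compounds shown, so a change at this position can be partly read for the first time. Isopropyl in place of ethyl gives an at least 1.2-fold lower number from compound 1 to compound 3 (0.11 log units; that floor lies within the scatter). The step can be stated only as a floor because compound 1 stands at a limit of the assay: the limit of >= 240000 nM in this assay, at which 1 of the 3 values shown sits.

On these data alone, the true size of this step remains open. So does whether a longer chain such as n-butyl, or an amine, at this position would leave the number within the scatter.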